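Notes on a methoxy-for-hydroxy step in the series

The source may report more compounds than this note shows. Statements on the series, on what has been measured and on what is new or still open speak of the compounds shown alone.

For the measured compounds named here, compound 1 `Cc1cc(O)nc(NC(=S)NC(=O)c2c(-c3ccc(Cl)cc3Cl)noc2C)n1` is one of two compounds measured in a functional assay on the whole organism for inhibition, with Chenopodium ficifolium as the target, with a stated time of 72 h, tested at 10 mg/L; a higher number here means more inhibition of growth at the concentration tested, a lower number less inhibition of growth. In this assay compound 1 gives -5.86%, the lowest of the two numbers. Compound 2 `COc1cc(Cl)nc2n/c(=N/C(=O)c3c(-c4ccc(Cl)cc4Cl)noc3C)sn12` in this assay gives 19.3%, a number beyond the scatter higher than compound 1; compound 2 differs from compound 1 in more than one place, so the two values show only that much. Compound 3 `COc1cc(C)nc(NC(=S)NC(=O)c2c(-c3ccc(Cl)cc3Cl)noc2C)n1` is not yet measured. It differs from compound 1 by a single change, (methyl in place of hydrogen on an oxygen on an aromatic ring). Going by the values given here, no step of this kind between two measured compounds exists, so only a small step is expected, at most near the edge of the scatter, with the direction uncertain. The step from compound 1 to compound 3 is expected to be a number 9.9 percentage points higher from compound 1 to compound 3 (within the scatter) in this assay. For compound 3 the estimate in this assay is 4%, within a range from -15% to 28%.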

Compound 3, percent growth inhibition at one concentration: 15.3%
For compound 3 the middle estimate is 11.3 percentage points below the measured one, within the range that was stated.
By their numbers in this assay, from the lowest: compound 1; then compounds 3 and 2 (each within the scatter of the next).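

Working notes on the hydroxy-to-methoxy change: the step of a number 21.2 percentage points higher from compound 1 to compound 3 (beyond the scatter) in this assay is the first reading in the series of a change in one place only. It shows that the group on this oxygen matters for growth inhibition at the concentration tested, with methyl in place of hydrogen giving the higher number. The earlier compounds differed in more than one place and could not show this, and nothing available explains the step.

As far as these compounds go, whether the higher number follows from the loss of the hydrogen or from the added methyl remains open, and a longer chain such as ethyl on the same oxygen, or an amine in place of the hydroxy group, would help to separate the two. From the compounds shown here alone, whether the step holds at other concentrations or on other plant species also remains open.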